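Replacing the Ethoxycarbonyl Group of Compound 3

The compounds below may be only part of what the source reports. "The series", "measured", "known", "first", "only" and "open" are said of these compounds alone.

In a functional assay on HeLa cells (Homo sapiens) for cytotoxicity, read by resazurin assay, with a stated time of 72 h (on this read-out lower numbers stand for stronger inhibition and higher numbers for weaker inhibition), compound 1 (`CCSC(=S)SCC(=O)c1cccc(C(=O)Nc2ccccc2)c1`) gives 2400 nM, and compound 2 (`CCSC(=S)SCC(=O)c1cccc(NS(=O)(=O)c2ccc(Cl)cc2)c1`) gives 46600 nM. Compound 3 (`CCOC(=O)SCC(=O)c1ccc(OC)cc1`) gives 18500 nM, the middle of the three numbers, lying beyond the scatter from each of the other two. Compound 4 (`CCNC(=S)SCC(=O)c1ccc(OC)cc1`) has not yet been measured. It differs from compound 3 on a sulfur: a group of 5 heavy atoms (3 carbon, 1 nitrogen, 1 sulfur; no ring) in place of a group of 5 heavy atoms (3 carbon, 2 oxygen; no ring), on a sulfur. Going by the values given here, no measured pair differs in a single place, so the data offer no direct guide to this change. The estimated change, a 1.5-fold lower number from compound 3 to compound 4 (0.19 log units; within the scatter), is expected to lean towards a lower number without going beyond the scatter. For compound 4, the estimated value is 12000 nM, with an expected range of 4000 nM to 35000 nM.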

Compound 4, half-maximal inhibitory concentration: 7800 nM
Estimate against measurement, compound 4: 1.5-fold (0.19 log units) above; the range from low to high includes it.
By their numbers in this assay, from the lowest: compound 1; then compound 4; then compound 3; then compound 2.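

In this assay, going by these compounds alone, the exchange of the ethoxycarbonyl group on this sulfur brings a 2.4-fold lower number from compound 3 to compound 4 (0.38 log units; beyond the scatter) and so shows that this position responds to the change, which the earlier compounds, differing in more than one place, could not show. The entering group differs in both its nitrogen and its sulfur, and this single step does not separate the two. Nothing available accounts for the step.

The compounds shown leave open whether a longer chain on that nitrogen, or a morpholine ring in its place, would lower the number further. They also leave open whether the same exchange would act alike on the core of compound 1.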